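Ring Contraction on the Amide Nitrogen of Compound 3

This account rests on a few compounds, and the source may have more. Where it says the series, first, only, none or still open, it means among the compounds named here.

Three compounds have been measured in an ADME assay on microsomes from liver (Mus musculus, strain CD-1) for metabolic stability, read by LC-MS, tested at 2 uM; a higher number here means that the compound lasts longer, a lower number that the compound disappears faster:

Compound 1 `Cn1ccc2ccc(-c3cc(Nc4ccccc4S(=O)(=O)Nc4cncnc4)cc4nccnc34)cc21` gives 0.683 h.
Compound 2 `Cn1cc(CNC(=O)c2ccncc2Nc2cc(-c3ccc4ccn(C)c4c3)c3nccnc3c2)cn1` gives 0.267 h.
Compound 3 `CC(=O)N1CCCC(NC(=O)c2ccncc2Nc2cc(-c3ccc4ccn(C)c4c3)c3nccnc3c2)C1` gives 0.4 h.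

Compound 3 sits between the other two, and all three numbers fall within the scatter of one another, so no real separation is seen. Compound 4 `CC(=O)N1CCC(NC(=O)c2ccncc2Nc2cc(-c3ccc4ccn(C)c4c3)c3nccnc3c2)C1` differs from compound 3 in one place: 1-acetylpyrrolidin-3-yl in place of 1-acetylpiperidin-3-yl on an amide-type nitrogen. Going by the values given here, the only measured step bearing on this position is a 1.5-fold higher number from compound 2 to compound 3 (0.18 log units; within the scatter), which swapped the group on the same amide-type nitrogen and stayed within the scatter. Among the compounds with values here, no step trades a six-membered for a five-membered ring here. For compound 4 the expectation is therefore no change at the digits printed from compound 3 to compound 4 (within the scatter), nothing beyond the scatter. Compound 4 is estimated at 0.4 h, ranging from 0.2 h to 0.8 h.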

Compound 4, half-life: 0.667 h
The estimate for compound 4 lay 1.7-fold (0.22 log units) below the measured number; the measured number falls inside the stated range.
By their numbers in this assay, from the lowest: compounds 2, 3, 4 and 1 (each within the scatter of the next, the first and the last beyond it).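

Going from 1-acetylpiperidin-3-yl to 1-acetylpyrrolidin-3-yl on the amide-type nitrogen gives a step in this assay that cannot be told apart from noise (a 1.7-fold higher number from compound 3 to compound 4 (0.22 log units; within the scatter)). Set against (1-methyl-1H-pyrazol-4-yl)methyl, however, 1-acetylpyrrolidin-3-yl gives the first modest step at this position that clears the scatter (a 2.5-fold higher number from compound 2 to compound 4 (0.40 log units; beyond the scatter)), so the group on this nitrogen can shift the half-life. No measurement here explains why. On these data alone, what a smaller azetidine ring, or a free amine in place of the acetyl group, would do at this position remains open.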